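A few compounds are considered here, and "the series" means these few. Any claim that something is new, unique, unknown or untested is made for them only; others in the source may bear on it.

Compound 1 `CC(C)C[C@H]1C[C@@H](Cl)CCO1` gives, as a limit of the assay, > 100000 nM in a functional assay on SW1573 cells (Homo sapiens) for antiproliferative activity; a lower number here means a stronger inhibitor of growth, a higher number a weaker inhibitor of growth.
Compound 2 `CC(C)C[C@H]1C[C@@H](Cl)C[C@@H](C)O1` gives, as a limit of the assay, > 100000 nM in this assay.

Compound 2 thus stands at the limit of > 100000 nM in this assay, at which 2 of the 2 values shown sit, so its true potency is not known, only that it is weak. Compound 3 `CC(C)C[C@@H]1C[C@H](Cl)C[C@H](CC(C)C)O1` differs from compound 2 by isopropyl in place of hydrogen on a saturated chain carbon bound to a saturated ring carbon. Going by the values given here, the one measured step, a step that the two limits leave unreadable from compound 1 to compound 2, cannot be read, because both of its ends are limits; no measured step therefore gives a size to expect for this change. Compound 3 is estimated at 150000 nM, within a range of 30000 nM to 500000 nM. The expected step is a step that the limit leaves unreadable from compound 2 to compound 3, most likely again ending at a limit.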

Compound 3, concentration for 50% growth inhibition: 67000 nM
Beside the measured number, compound 3's estimate is 2.2-fold (0.35 log units) above it; the measured number falls inside the stated range.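

Going by these compounds alone, with isopropyl in place of hydrogen on a saturated chain carbon bound to a saturated ring carbon, compound 3 gives the first number in this assay that is not a limit, a step of an at least 1.4-fold lower number from compound 2 to compound 3 (0.17 log units; that floor lies within the scatter). The same compound also shows an at least 1.4-fold lower number from compound 1 to compound 3 (0.17 log units; that floor lies within the scatter). Both steps are only floors, since the other two compounds sit at a limit: the limit of > 100000 nM in this assay, at which 2 of the 3 values shown sit.

The step from compound 1 to compound 2 cannot be read. From the compounds shown here alone, whether a longer chain, an amine or a carboxylic acid at this place would lower the number further remains open.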